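A few compounds are considered here, and "the series" means these few. Any claim that something is new, unique, unknown or untested is made for them only; others in the source may bear on it.

Measured compounds:

Compound 1, `Oc1ccc2c(O)cc(-c3ccccc3)nc2c1`: > 10 ug/mL
Compound 2, `Oc1cc(-c2ccccc2)nc2cc(F)ccc12`: 3.45 ug/mL
Compound 3, `Oc1cc(-c2ccccc2)nc2c(O)cccc12`: > 10 ug/mL

The three compounds were tested in a functional assay on HCT-8 cells (Homo sapiens) for cytotoxicity; on this read-out lower numbers stand for an effect already at smaller amounts and higher numbers for an effect only at larger amounts of compound. For compound 1 the result is only a limit of the assay, > 10 ug/mL. Compound 2 gives a number, 3.45 ug/mL. Among the compounds with values here, the one change between them, (fluoro in place of hydroxy on an aromatic carbon), produced an at least 2.8-fold lower number from compound 1 to compound 2 (0.46 log units; beyond the scatter). For compound 3 the result is again only a limit, > 10 ug/mL. Compound 3 and compound 1 share the same atoms joined differently; the difference between the two cores is not broken down here. Of the three values, the limit of > 10 ug/mL in this assay, at which 2 of the 3 values shown sit, marks where most of them sit.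

Compound 4, `Oc1cc(-c2ccccc2)nc2c(F)cccc12`, has not yet been measured in this assay. It differs from compound 3 by fluoro in place of hydroxy on an aromatic carbon. Within the data shown here, this is the same kind of change as the one from compound 1 to compound 2, but the surroundings of the place differ: in the measured pair the group is meta to a fused ring and para to a fused ring, whereas in compound 4 it is ortho to a fused ring and meta to a fused ring. Because the measured step of an at least 2.8-fold lower number from compound 1 to compound 2 (0.46 log units; beyond the scatter) took the value out of the limit region, a step of similar direction is expected from compound 3 to compound 4, estimated as an at least 2.0-fold lower number from compound 3 to compound 4 (0.30 log units; that floor lies within the scatter). Compound 4 is accordingly estimated to give about 5 ug/mL in this assay, expected between 2 ug/mL and 15 ug/mL, with the caveat that compound 3 itself is known only as a limit, so the starting point of the step is uncertain.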

Compound 4, half-maximal effective concentration: 0.04 ug/mL
Compound 4: the middle estimate sits 130-fold (2.10 log units) above what was measured, and the stated range ends above it.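

In this assay, fluoro in place of hydroxy on an aromatic carbon gave an at least 250-fold lower number from compound 3 to compound 4 (2.39 log units; beyond the scatter), so the number fell on both cores and the direction of the change carried over from the core of compound 1 to the core of compound 3: the same change on two cores in this assay, an at least 2.8-fold lower number (0.46 log units; beyond the scatter) from compound 1 to compound 2 and an at least 250-fold lower number (2.39 log units; beyond the scatter) from compound 3 to compound 4; the limit leaves it open whether they differ

What this does not show is a size that travels with the change: compound 1 and compound 3 are each known only as a limit, so neither step has a known full size and no gap between the two can be stated. Two pairs are also too few to predict the change on any further core, and the core cannot be separated from the place of the group, which in compound 4 is ortho to a fused ring and meta to a fused ring and differs in the earlier pair.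

The compounds shown leave open how other groups at these places would read, such as chloro, methoxy or an amine, and how the same place would read with hydrogen alone. They also leave open whether the low number of compound 4 would hold outside this assay.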